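Iodo to propyl on the aryl amine of compound 1

The compounds below may be only part of what the source reports. "The series", "measured", "known", "first", "only" and "open" are said of these compounds alone.

Measured in a functional assay on HeLa cells (Homo sapiens) for inhibition, read by sulforhodamine B assay; a higher number here means a weaker inhibitor, a lower number a stronger inhibitor:
compound 1 `O=C1C=C(Nc2ccc(I)cc2)C(=O)c2c1nc1n2[C@H]2OC[C@@H](O)[C@H]2OC1`, 4070 nM
compound 2 `COc1cccc(NC2=CC(=O)c3c(nc4n3[C@H]3OC[C@@H](O)[C@H]3OC4)C2=O)c1`, > 8000 nM
compound 3 `O=C1C(Nc2ccccc2F)=CC(=O)c2c1nc1n2[C@H]2OC[C@@H](O)[C@H]2OC1`, 9820 nM

Compound 1 stands lowest of the two readable numbers. Compound 3 is the nearest to it and sits higher, beyond the scatter. The value of compound 2 is a limit of this assay and not a number. Going by the values given here, the only step measured within the set, a step that the limit leaves unreadable from compound 2 to compound 3, is left unreadable by the limit of > 8000 nM in this assay, at which 1 of the 3 values shown sits.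

Compound 4 `CCCc1ccc(NC2=CC(=O)c3nc4n(c3C2=O)[C@H]2OC[C@@H](O)[C@H]2OC4)cc1` differs from compound 1 in one place: propyl in place of iodo on an aromatic carbon. Among the compounds with values here, no measured step changes the group on that aromatic carbon, and the one step among the aryl amines, a step that the limit leaves unreadable from compound 2 to compound 3, gives no readable size. Within the data shown here, nothing among the measured compounds therefore supports a direction for this change in this assay. The expected step is a 1.2-fold higher number from compound 1 to compound 4 (0.09 log units; within the scatter), within the scatter, with a wide range to reflect the lack of a guiding step. Compound 4 is estimated to give 5000 nM, between 2000 nM and 12000 nM.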

Compound 4, half-maximal inhibitory concentration: 4990 nM
Compound 4: the middle estimate sits 1.0-fold (0.00 log units) above what was measured; the measured number falls inside the stated range.
By their numbers in this assay, from the lowest: compounds 1, 4 and 3 (each within the scatter of the next, the first and the last beyond it).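

In this assay, going by these compounds alone, propyl in place of iodo gives a 1.2-fold higher number from compound 1 to compound 4 (0.09 log units; within the scatter), the only readable step that changes a group on the aryl amine. On this aromatic carbon, para to a large group, the 4-iodophenyl and 4-propylphenyl versions of the shared core are therefore not told apart by this read-out, although the group changes from 1 heavy atom to 3 heavy atoms, so the position accepts at least these two groups without a change beyond the scatter. Nothing measured here gives a reason for this step.

From the compounds shown here alone, whether the same holds for other groups on this aromatic carbon, such as an amine, a carboxylic acid or a chain longer than propyl, stays open, and two groups without a readable difference do not define a trend at this position. The step from compound 2 to compound 3 cannot be read, which leaves open how the other aryl amines of the series relate to one another in this assay.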